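Series notes: carboxy replaced by 2-chlorophenyl on chain carbon

A few compounds are considered here, and "the series" means these few. Any claim that something is new, unique, unknown or untested is made for them only; others in the source may bear on it.

Compound 1 `Cc1[nH]n(-c2ccccn2)c(=O)c1C` returns no number. In an assay on isolated protein for inhibition of alpha-ketoglutarate-dependent dioxygenase alkB homolog 3 (Homo sapiens), read by polymerase chain reaction, with a stated time of 1 h (on this read-out lower numbers stand for stronger inhibition and higher numbers for weaker inhibition), compound 1 gives > 10000 nM, which is a limit of the assay rather than a measured value. Compound 2 `Cc1[nH]n(-c2nc3ccccc3[nH]2)c(=O)c1CC(=O)O` carries a carboxymethyl chain on the shared core. In this assay compound 2 gives 15000 nM. Going by the values given here, compound 2 therefore holds the only number in the set so far, the remaining entry being the limit described as the limit of > 10000 nM in this assay, at which 1 of the 2 values shown sits. Compound 3 `Cc1[nH]n(-c2nc3ccccc3[nH]2)c(=O)c1Cc1ccccc1Cl` is not yet measured. It differs from compound 2 by 2-chlorophenyl in place of carboxy on a saturated chain carbon bound to an aromatic carbon, so that the carboxymethyl becomes a 2-chlorobenzyl. Among the compounds with values here, no measured step covers this change, and the two results to hand give no direction for it. A modest gain is nevertheless expected, with the step estimated as a 2.1-fold lower number from compound 2 to compound 3 (0.33 log units; beyond the scatter). Compound 3 is accordingly expected at 7000 nM, within 1500 nM to 40000 nM, and a limit-only result remains a real possibility.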

Compound 3, half-maximal inhibitory concentration: > 10000 nM
Compound 3: a limit, no number (the forecaster's own chance of this, stated with the estimate: 30%); at least 1.4-fold (0.15 log units) between middle value and limit.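

In this assay compound 3 gives > 10000 nM, which is a limit and not a number, so the step from compound 2 to compound 3 cannot be read. The compounds shown leave open whether 2-chlorobenzyl in place of carboxymethyl changes inhibition at all.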